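This account rests on a few compounds, and the source may have more. Where it says the series, first, only, none or still open, it means among the compounds named here.

Compound 1 `O=c1[nH]ccn1CCOc1nn(-c2ccccc2F)c2ccc(F)cc12`: 200 mL/min/kg
Compound 2 `CC(Oc1nn(-c2ccccc2F)c2ccc(F)cc12)C(=O)N1CCOCC1`: 317 mL/min/kg
Compound 3 `O=C1N(c2ccncc2)CCN1c1cccc2c1cnn2-c1ccccc1F`: 63.3 mL/min/kg

All three values come from an ADME assay on liver for metabolic stability, with Liver microsome (Homo sapiens) as the target, using microsomes and NADPH, with a stated time of 30 min, tested at 0.5 uM; on this read-out lower numbers stand for slow clearance and higher numbers for fast clearance. Compound 1 lies within the scatter of compound 2, and it stands higher than compound 3, a gap beyond the scatter.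

Compound 4 `O=C1OCCN1CCOc1nn(-c2ccccc2F)c2ccc(F)cc12` has not yet been measured. It keeps the core of compound 1 and changes one group: a group of 6 heavy atoms (3 carbon, 1 nitrogen, 2 oxygen; one five-membered non-aromatic ring with 2 hetero atoms) in place of a group of 6 heavy atoms (3 carbon, 2 nitrogen, 1 oxygen; one five-membered aromatic ring with 2 hetero atoms), on a saturated chain carbon, two bonds along the chain from an oxygen on an aromatic ring. The new group, 2-oxo-1,3-oxazolidin-3-yl, sits on a saturated chain carbon, two bonds along the chain from an oxygen on an aromatic ring.

Among the measured compounds shown here, no measured pair isolates a change of this kind, so the expectation is uncertain. Compound 2 at 317 mL/min/kg has a different side chain on the shared core, yet remains within the scatter of compound 1. No step beyond the scatter is therefore expected in this assay. The estimated step is a 1.1-fold higher number from compound 1 to compound 4 (0.04 log units; within the scatter). For compound 4 the expected value is 220 mL/min/kg, with an estimated range of 110 mL/min/kg to 400 mL/min/kg.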

Compound 4, clearance: 683 mL/min/kg
The estimate for compound 4 lay 3.1-fold (0.49 log units) below the measured number; measured number above the stated range.
By their numbers in this assay, from the lowest: compound 3; then compounds 1 and 2 (each within the scatter of the next); then compound 4.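

Notes on the side chain: the group on a saturated chain carbon, two bonds along the chain from an oxygen on an aromatic ring, is not neutral in this assay, since replacing the five-membered aromatic ring with 2-oxo-1,3-oxazolidin-3-yl gives a 3.4-fold higher number from compound 1 to compound 4 (0.53 log units; beyond the scatter) on the shared core. The two groups match in heavy-atom count and differ in ring aromaticity, in ring atoms and in the hydrogen-bond donor present only in the leaving group, so similar size alone does not preserve clearance at this position. No supporting measurement explains the step.

This single pair cannot separate those differences, leaving open how a 2-oxopyrrolidin-1-yl ring would read. Also open, going by these compounds, is whether the step persists when 2-oxo-1,3-oxazolidin-3-yl sits on a longer chain.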